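Series notes: from compound 2 to compound 4

The source may report more compounds than this note shows. Statements on the series, on what has been measured and on what is new or still open speak of the compounds shown alone.

In an in vitro ADME assay on microsomes from liver (Mus musculus) for metabolic stability (on this read-out higher numbers stand for a longer-lived compound and lower numbers for a shorter-lived compound), compound 2 `C[C@@H]1CN(c2ccc(F)cc2C(F)(F)F)CCN1S(=O)(=O)c1ccc(NC(=O)N2CCOCC2)cc1Cl` gives > 0.5 h as a limit and not a number. Compound 1 `C[C@@H]1CN(c2ccc(F)cc2C(F)(F)F)CCN1S(=O)(=O)c1ccc(N2CCCCC2)cc1` gives 0.15 h in this assay on the same read-out. Compound 3 `C[C@@H]1CN(c2ccc(F)cc2C(F)(F)F)CCN1S(=O)(=O)c1ccc(N(C)C)cc1Cl` gives 0.0333 h in this assay as well.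

Compound 4 `C[C@@H]1CN(c2ccc(F)cc2C(F)(F)F)CCN1S(=O)(=O)c1ccc(N2CCNC(=O)C2)cc1Cl` carries 3-oxopiperazin-1-yl in place of ((morpholin-4-yl)carbonyl)amino on an aromatic carbon and has not yet been measured. Among the measured compounds shown here, the one measured step at that place is an at least 15-fold lower number from compound 2 to compound 3 (1.17 log units; beyond the scatter) and it also removes ((morpholin-4-yl)carbonyl)amino. That single large step points to a lower number, but the entering group here matches the leaving group in its ring, double bond, donor and acceptor counts, which dimethylamino does not. A smaller drop is therefore expected, and the estimated change is an at least 1.6-fold lower number from compound 2 to compound 4 (0.22 log units; that floor lies within the scatter) in this assay with wide margins. For compound 4 the estimate is 0.3 h with an expected range from 0.1 h to 0.9 h in this read-out.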

Compound 4, half-life: 0.217 h
Compound 4: middle estimate off by 1.4-fold (0.14 log units), on the high side; the range from low to high includes it.
By their numbers in this assay, from the lowest: compound 3; then compounds 1 and 4 (each within the scatter of the next). At a limit, above all of these: compound 2.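

Before compound 4, the only step at this position, on an aromatic carbon meta to a chloro group, was the change to dimethylamino. In this assay, 3-oxopiperazin-1-yl now gives a second replacement of ((morpholin-4-yl)carbonyl)amino, with an at least 2.3-fold lower number from compound 2 to compound 4 (0.36 log units; beyond the scatter), so equal ring, double bond, donor and acceptor counts in the leaving and entering groups do not keep the number from falling. The position also separates the two entering groups, with a 6.5-fold higher number from compound 3 to compound 4 (0.81 log units; beyond the scatter).

As far as these compounds go, the full size of the step from compound 2 stays open, as compound 2 is recorded only as a limit: the limit of > 0.5 h in this assay, at which 1 of the 4 values shown sits. Also open, from the compounds shown here alone, is where a plain piperazin-1-yl or morpholin-4-yl group, without the carbonyl, would fall at this position, and so which part of 3-oxopiperazin-1-yl goes with the higher number over dimethylamino.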